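A few compounds are considered here, and "the series" means these few. Any claim that something is new, unique, unknown or untested is made for them only; others in the source may bear on it.

In a functional assay on aorta (Rattus norvegicus, strain Sprague-Dawley) for inhibition (on this read-out higher numbers stand for an effect only at larger amounts of compound and lower numbers for an effect already at smaller amounts), compound 1 (`CCCCCCOc1cc2c(c3c1C[C@@H]1[C@@H](C)CO[C@]1(C)O3)C[C@@H]1[C@@H](C)CO[C@]1(C)O2`) gives > 200000 nM as its read-out, which is a limit of the assay and not a number. Compound 1 therefore stands at that limit (the limit of > 200000 nM in this assay, at which 1 of the 2 values shown sits). Compound 2 (`C[C@H]1CO[C@]2(C)Oc3cc(OC/C=C/c4ccccc4)c4c(c3C[C@H]12)O[C@@]1(C)OC[C@H](C)[C@H]1C4`), with 2-phenylethenyl in place of pentyl on a saturated chain carbon bound to an oxygen on an aromatic ring, gives 64000 nM in the same test.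

Compound 3 (`CCCCOc1cc2c(c3c1C[C@@H]1[C@@H](C)CO[C@]1(C)O3)C[C@@H]1[C@@H](C)CO[C@]1(C)O2`) differs from compound 1 in a shorter chain, with hydrogen in place of ethyl on a saturated chain carbon, four bonds along the chain from an oxygen on an aromatic ring. Among the compounds with values here, only one measured step bears on this chain (an at least 3.1-fold lower number from compound 1 to compound 2 (0.49 log units; beyond the scatter)), and it brought in 2-phenylethenyl. No such group enters here, so that step offers only a loose guide, and no change beyond the scatter is expected in this assay. A second reading at the limit is quite possible. The expected step is small (a number no higher from compound 1 to compound 3 (the limit leaves the size open)). For compound 3 the estimated value is 200000 nM (expected range 70000 nM to 500000 nM).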

Compound 3, half-maximal effective concentration: 111000 nM
Estimate against measurement, compound 3: 1.8-fold (0.26 log units) above; measured number inside the range.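

The 2-phenylethenyl group turns out not to be needed for a measurable reading at this position: propyl in its place gives a 1.7-fold higher number from compound 2 to compound 3 (0.24 log units; within the scatter), so in this assay the two compounds cannot be told apart. A plain saturated chain, once shorter, therefore reads in the same range as the chain carrying an aromatic ring, and the earlier step alone could not show this. Hydrogen in place of ethyl gives an at least 1.8-fold lower number from compound 1 to compound 3 (0.25 log units; that floor lies within the scatter), so the true size of this shortening stays unknown, and it may be small or large, as compound 1 remains the only reading that is a limit and not a number: the limit of > 200000 nM in this assay, at which 1 of the 3 values shown sits.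

Going by these compounds, whether a still shorter chain, such as ethyl, would move the number beyond the scatter remains open. On these data alone, it is also open whether an amine or a carboxylic acid on this chain would bring the effect down to clearly smaller amounts of compound than any seen here.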